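A few compounds are considered here, and "the series" means these few. Any claim that something is new, unique, unknown or untested is made for them only; others in the source may bear on it.

The three compounds measured here share one core and differ in the groups on its aromatic rings or in the drawn configuration of a single carbon. Compound 1 `CCc1ccc(NC(=O)N[C@H](C)c2ccccc2)cc1` is the starting point. In an ADME assay on the whole organism with Oryza sativa as the target, tested at 1 uM (a higher number here means a weaker effect of the compound at the concentration tested, a lower number a stronger effect), compound 1 gives 47%, the lowest of the three numbers recorded; both other compounds lie far above it. Compound 2 `CCc1ccc(NC(=O)N[C@@H](C)c2ccccc2)cc1` gives 95%, and compound 3 `CC(=O)c1ccccc1NC(=O)N[C@@H](C)c1ccccc1` gives 97%.

Within the data shown here, only one measured step joins two compounds that differ in a single place: a number 48 percentage points higher from compound 1 to compound 2 (beyond the scatter). This step rests on (the fact that compounds 1 and 2 differ only in the configuration as drawn), and it concerns configuration only, not the substituents on the rings.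

Compound 4 `C[C@@H](NC(=O)Nc1ccc(I)cc1)c1ccccc1` is the next compound to be measured. It differs from compound 1 in one place: iodo in place of ethyl on an aromatic carbon. Among the measured compounds shown here, no measured step tells what exchanging a group on that aromatic carbon does in this assay, so the one large step seen so far gives no guidance here, and nothing measured points in either direction. In this assay compound 4 is therefore expected to give about 55%, with a range from 25% to 85%. The step this expectation implies, a number 8 percentage points higher from compound 1 to compound 4 (within the scatter), is estimated to stay close to the scatter, but the uncertainty is wide.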

Compound 4, a percentage reported as activity, at one concentration (the size of the read-out at that concentration, not a potency): 91%
Compound 4: middle estimate off by 36 percentage points, on the low side, outside the stated range (above it).
By their numbers in this assay, from the lowest: compound 1; then compounds 4, 2 and 3 (each within the scatter of the next).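

Among these compounds, this is the first measured sign that the group on this aromatic carbon, para to a large group, matters in this assay and not only the drawn configuration: with iodo in place of ethyl, the result is a number 44 percentage points higher from compound 1 to compound 4 (beyond the scatter). The stronger effect of compound 1 is therefore lost through a single exchange on the ring, just as it was lost through the change of configuration seen earlier, so it depends on both features of that compound. Among the compounds shown here, nothing at hand explains why exchanging ethyl for iodo has so large an effect, since the only available information concerns configuration, not this group.

A single exchange cannot show whether ethyl is special at this position or whether iodo is simply a poor replacement; a methyl group, a longer chain such as propyl, a chloro group, an amine or a carboxylic acid on the same carbon would help to separate these two readings. On these data alone, it also remains open how iodo behaves when the configuration of the chain carbon is drawn the other way.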